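The source may hold more compounds than are shown below. What is called first, only, known or untested is meant among the compounds shown, and "the series" means these compounds.

Measured in a functional assay on the whole organism with Oryctolagus cuniculus as the target; a lower number here means a stronger inhibitor, a higher number a weaker inhibitor:
compound 1 `CO/C(O)=C1\C(C)=Nc2ccccc2SC1c1cccc([N+](=O)[O-])c1`: 1200 nM
compound 2 `CO/C(O)=C1\C(C)=Nc2ccccc2SC1c1ccccc1[N+](=O)[O-]`: 300 nM
compound 3 `CO/C(O)=C1\C(C)=Nc2ccccc2SC1c1ccc([N+](=O)[O-])cc1`: 3000 nM

All three compounds share one core and carry a nitro group, and they differ in where that group sits on the six-membered aromatic ring. In this assay, compound 3 has the highest number of the three, at 3000 nM, and so is the weakest inhibitor. Its gaps to compound 1 and compound 2 both lie beyond the scatter, and the gap to compound 2 is the wider.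

Compound 4 `CO/C(O)=C1\C(C)=Nc2ccccc2SC1c1ccc(OC)cc1` has not yet been measured. It keeps the shared core and has methoxy in place of nitro on an aromatic carbon, para to a large group: methoxy in place of nitro on an aromatic carbon. For the measured compounds named here, no measured pair shows what this exchange does, so the expectation rests on compound 3, at 3000 nM, as the closest reference. A small shift towards a lower number is expected, and it is not expected to go beyond the scatter: the estimated change is a 1.2-fold lower number from compound 3 to compound 4 (0.08 log units; within the scatter). The range is kept wide, since moving the nitro alone separates compound 2, at 300 nM, from compound 3, at 3000 nM. For compound 4 the expected value is 2500 nM, with an estimated range from 600 nM to 10000 nM.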

Compound 4, half-maximal inhibitory concentration: 22000 nM
Beside the measured number, compound 4's estimate is 8.8-fold (0.94 log units) below it; measured number outside the range, above it.
By their numbers in this assay, from the lowest: compound 2; then compound 1; then compound 3; then compound 4.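

In this assay, the exchange of nitro for methoxy on an aromatic carbon, para to a large group, gives a 7.3-fold higher number from compound 3 to compound 4 (0.87 log units; beyond the scatter). The earlier compounds shown here showed only that moving the nitro around the six-membered aromatic ring changes the number. This step shows that, with the position held fixed, the choice of group also matters, and that the number at this position can rise well past that of compound 3. Nothing given here explains why the exchange has an effect of this size. As far as these compounds go, whether an amine, a carboxylic acid or a chlorine atom on this same carbon would fall nearer to compound 3 or nearer to compound 4 remains open, as does the direction of any such change. From the compounds shown here alone, it is also open whether methoxy in place of nitro would produce a similar step at the positions where the nitro sits in compound 1 and compound 2, so the step cannot yet be said to hold beyond this one position.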